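A few compounds are considered here, and "the series" means these few. Any claim that something is new, unique, unknown or untested is made for them only; others in the source may bear on it.

Compound 1 `Cc1ccc(-c2nc(CNc3ccc(C(=O)NO)cc3)n(-c3ccccc3)n2)o1` gives 60.7% in an assay on Sf9 cells for inhibition of protein deacetylase HDAC6 (Homo sapiens), read by fluorescence, with a stated time of 40 min, tested at 100 nM; on this read-out lower numbers stand for less inhibition and higher numbers for more inhibition at the one concentration tested (going by the name of the read-out).
Compound 2 `Cc1ccccc1-c1nc(CNc2ccc(C(=O)NO)cc2)n(-c2ccccc2)n1` gives 53.2%.
Compound 3 `O=C(NO)c1ccc(NCc2nc(-c3ccco3)nn2-c2ccccc2)cc1` gives 59.9%.

All three numbers sit close together: compound 3 differs from its neighbours only by a number 0.8 percentage points lower from compound 1 to compound 3 (within the scatter) and a number 6.7 percentage points higher from compound 2 to compound 3 (within the scatter), so none of the three can be called stronger or weaker than another. Compound 4 `O=C(NO)c1ccc(NCc2nc(-c3ccc(Br)o3)nn2-c2ccccc2)cc1` carries bromo in place of hydrogen on an aromatic carbon. Going by the values given here, the one measured step at the same carbon is a number 0.8 percentage points lower from compound 1 to compound 3 (within the scatter), which stayed within the scatter; exchanging the whole ring, as in a number 7.5 percentage points lower from compound 1 to compound 2 (within the scatter) and a number 6.7 percentage points higher from compound 2 to compound 3 (within the scatter), also stayed within it. A small swap at this spot is therefore expected to move this assay little, if at all, and the step of a number 0.1 percentage points higher from compound 3 to compound 4 (within the scatter) is the expected one. Compound 4 is estimated at 60%, between 45% and 75%.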

Compound 4, a percentage reported as inhibition, at one concentration (the size of the read-out at that concentration, not a potency): 55.8%
For compound 4 the middle estimate is 4.2 percentage points above the measured one; the range from low to high includes it.
By their numbers in this assay, from the lowest: compounds 2, 4, 3 and 1 (each within the scatter of the next).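

In this assay, the step to bromo on this carbon next to the ring oxygen, a number 4.1 percentage points lower from compound 3 to compound 4 (within the scatter), shows that hydrogen, methyl and now a single bromine atom all give numbers that cannot be told apart here. The same holds for bromo against methyl, a number 4.9 percentage points lower from compound 1 to compound 4 (within the scatter), and for 5-bromofuran-2-yl against 2-methylphenyl, a number 2.6 percentage points higher from compound 2 to compound 4 (within the scatter). No measurement available here explains this flat picture. On these data alone, whether an amine, a carboxylic acid or a longer chain at this carbon would also leave the number unmoved remains open.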